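Solubility notes: fluoro added to compound 2

This account rests on a few compounds, and the source may have more. Where it says the series, first, only, none or still open, it means among the compounds named here.

Measured so far in a physicochemical assay for solubility, using the shake flask method, measured as kinetic solubility, at pH 7.4; on this read-out lower numbers stand for lower solubility and higher numbers for higher solubility:
Compound 1 `O=C(O)c1cccc(-c2nc(Nc3ccccc3F)cs2)c1`: > 100000 nM.
Compound 2 `O=C(O)c1cccc(-c2cnc(Nc3ccccc3F)o2)c1`: 55600 nM.

Compound 1 gives > 100000 nM in this assay, which is a limit of the assay and not a number; this is the entry described by the limit of > 100000 nM in this assay, at which 1 of the 2 values shown sits. Going by the values given here, compound 2 gives 55600 nM in this assay, and this is the only number recorded so far. Among the compounds with values here, no step between measured compounds that differ in one place is available, so nothing measured bears directly on small substitutions of this kind.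

Compound 3 `O=C(O)c1cccc(-c2cnc(Nc3ccc(F)cc3F)o2)c1` is not yet measured in this assay. It differs from compound 2 by fluoro in place of hydrogen on an aromatic carbon. Within the data shown here, with no measured step to lean on, the expectation is a small downward move in this assay, close to the usual scatter, given as a 1.4-fold lower number from compound 2 to compound 3 (0.14 log units; within the scatter). Compound 3 is therefore estimated at 40000 nM in this assay, with an expected range from 15000 nM to 100000 nM.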

Compound 3, solubility: 69000 nM
Compound 3: the middle estimate sits 1.7-fold (0.24 log units) below what was measured; the measured number falls inside the stated range.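

Fluoro in place of hydrogen on an aromatic carbon, para to a large group and meta to a fluoro group, gives a 1.2-fold higher number from compound 2 to compound 3 (0.09 log units; within the scatter) in this assay and is the first step in the series between compounds that differ in one place. On this single step, a fluoro group at this position of the six-membered aromatic ring leaves compound 2 and compound 3 within the scatter of each other, so the change shows no readable effect on this read-out. Compound 1 still holds only a limit of the assay and not a number, and it differs from the other compounds in more than one place, so it adds no step: the limit of > 100000 nM in this assay, at which 1 of the 3 values shown sits.

Still open, from the compounds shown here alone, is whether a group other than fluoro at this same position, such as an amine or a methoxy group, would give a step beyond the scatter. A single step also leaves open whether fluoro in place of hydrogen would read the same elsewhere on this ring or on the core of compound 1.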